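Amine variation on the shared core of compound 1

The compounds below may be only part of what the source reports. "The series", "measured", "known", "first", "only" and "open" are said of these compounds alone.

Measured compounds:
compound 1, `CCCN(C)c1cc(C)nc2c(-c3ccc(Cl)cc3Cl)nn(C)c12`, 24 nM
compound 2, `CCCCCN(CCCC)c1cc(C)nc2c(-c3ccc(Cl)cc3Cl)nn(C)c12`, 0.9 nM
compound 3, `CCCCN(CCCC)c1cc(C)nc2c(-c3ccc(OC)cc3Cl)nn(C)c12`, 4.8 nM

All three were measured in an assay on HEK293 cells for displacement of a labelled ligand from corticotropin-releasing factor receptor 1 (Homo sapiens); on this read-out lower numbers stand for stronger inhibition and higher numbers for weaker inhibition. Compound 1 gives the highest number of the three. The nearest value is that of compound 3, and the gap between them lies beyond the scatter; the value of compound 2 lies further from compound 1 still, also beyond the scatter. Going by the values given here, compounds 2 and 3 each differ from compound 1 in more than one place, so no single-point step between measured compounds is available.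

Compound 4 is `CCN(CCCOC)c1cc(C)nc2c(-c3ccc(Cl)cc3Cl)nn(C)c12`. It differs from compound 1 by ethyl(3-methoxypropyl)amino in place of methyl(propyl)amino on an aromatic carbon. The change keeps the same aryl substituent and the same core as compound 1 and alters only the amino group on that carbon.

The step from compound 1 to compound 4 in this assay is expected to go downward and to exceed the scatter, because compound 2, which also carries an amino group of more heavy atoms on that carbon, gives 0.9 nM. Among the compounds with values here, the extent is uncertain, since the entering group carries an oxygen that no measured compound has. The expected step is a 4.0-fold lower number from compound 1 to compound 4 (0.60 log units; beyond the scatter). For compound 4 the estimate is 6 nM, with a range from 2 nM to 20 nM.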

Compound 4, inhibition constant: 12.5 nM
For compound 4 the middle estimate is 2.1-fold (0.32 log units) below the measured one; low and high end bracket the measured number.
By their numbers in this assay, from the lowest: compound 2; then compound 3; then compounds 4 and 1 (each within the scatter of the next).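

In this assay, going by these compounds alone, ethyl(3-methoxypropyl)amino in place of methyl(propyl)amino on this aromatic carbon gives a 1.9-fold lower number from compound 1 to compound 4 (0.28 log units; within the scatter), the first step that can be read at a single place, and it leaves the two compounds without an order. The amino group at this position, opposite the ring nitrogen, thus goes from 5 to 8 heavy atoms and from 1 to 2 hydrogen-bond acceptors, with an oxygen entering, and the number shifts by no more than the scatter. On this one step, then, a larger amino group does not by itself go with a lower number, and no measurement at hand speaks to why the step is this small.

Still open, from the compounds shown here alone, is whether the oxygen of the entering chain counts for anything at this carbon, a question that ethyl(pentyl)amino on the same core and with the same aryl substituent would put directly. Also open, going by these compounds, is how a terminal hydroxyl, as in ethyl(3-hydroxypropyl)amino, or a ring amine such as morpholine would read at this position.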